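Adding a Methoxy Group to a Weakly Cytotoxic Scaffold

This account rests on a few compounds, and the source may have more. Where it says the series, first, only, none or still open, it means among the compounds named here.

Compound 3 `COc1cccc([C@H](O)[C@H]2CO[C@@H](c3ccc(OC)c(OC)c3)[C@H](C/C=C/c3ccc(OC)c(OC)c3)C2)c1` was tested in a functional assay on HeLa cells (Homo sapiens) for cytotoxicity, read by WST assay, with a stated time of 48 h (on this read-out lower numbers stand for stronger inhibition and higher numbers for weaker inhibition), where compound 3 gives 18600 nM. Two relatives share its core. In this assay compound 1 `COc1ccc(/C=C/C[C@@H]2C[C@@H]([C@@H](O)c3ccc(OC)c(OC)c3)CO[C@H]2c2ccccc2)cc1OC` gives 16100 nM, and compound 2 `COc1ccc(/C=C/C[C@@H]2C[C@H]([C@H](O)c3ccc(OC)c(OC)c3)CO[C@H]2c2ccc(OC)c(OC)c2)cc1OC` gives 28700 nM. Compound 3 lies within the usual scatter of both compound 1 and compound 2, so none of the three numbers can be set apart from the others with confidence.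

Compound 4 `COc1ccc(/C=C/C[C@@H]2C[C@@H]([C@@H](O)c3ccc(OC)c(OC)c3)CO[C@H]2c2ccc(OC)c(OC)c2)cc1OC` has not yet been measured. It differs from compound 3 in one place: methoxy in place of hydrogen on an aromatic carbon. Compound 1 already carries this group and gives 16100 nM, and compound 2 gives 28700 nM with the same group. The expected change a 1.1-fold higher number from compound 3 to compound 4 (0.03 log units; within the scatter) is therefore no larger than the scatter. Compound 4 is estimated at 20000 nM, with a range from 10000 nM to 40000 nM.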

Compound 4, half-maximal inhibitory concentration: 30600 nM
Beside the measured number, compound 4's estimate is 1.5-fold (0.18 log units) below it; measured number inside the range.
By their numbers in this assay, from the lowest: compounds 1, 3, 2 and 4 (each within the scatter of the next).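

Methoxy in place of hydrogen, which turns 3-methoxyphenyl into 3,4-dimethoxyphenyl, gives a 1.6-fold higher number from compound 3 to compound 4 (0.22 log units; within the scatter) in this assay, so this position now has a direct reading and it shows no clear effect. 3,4-Dimethoxyphenyl in place of phenyl on a saturated ring carbon also stays unresolved, with a 1.9-fold higher number from compound 1 to compound 4 (0.28 log units; within the scatter). Configuration can now be read as well, with a 1.1-fold higher number from compound 2 to compound 4 (0.03 log units; within the scatter), and this pair isolates it: the fact that compounds 2 and 4 differ only in the configuration as drawn

Still open, from the compounds shown here alone, is whether a different group at this position, such as an amine or a carboxylic acid, would give a step beyond the scatter.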